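From Methyl to Methoxy on a Shared Core

The source may hold more compounds than are shown below. What is called first, only, known or untested is meant among the compounds shown, and "the series" means these compounds.

Measured in a functional assay on HSC-2 cells (Homo sapiens) for cytotoxicity, with a stated time of 24 h; a higher number here means that more compound is tolerated, a lower number that less compound is tolerated:
Compound 1 `O=C1/C(=C/c2ccccc2)CCC/C1=C\c1ccccc1[N+](=O)[O-]`: 3800 nM
Compound 2 `CN(C)c1ccc(/C=C2\CCC/C(=C\c3ccccc3[N+](=O)[O-])C2=O)cc1`: > 400000 nM (a limit of the assay, not a number)
Compound 3 `Cc1ccc(/C=C2\CCC/C(=C\c3ccccc3[N+](=O)[O-])C2=O)cc1`: 11000 nM

Of the two true numbers, the higher belongs to compound 3 at 11000 nM. Compound 4 `COc1ccc(/C=C2\CCC/C(=C\c3ccccc3[N+](=O)[O-])C2=O)cc1` carries methoxy in place of methyl on an aromatic carbon. Going by the values given here, two measured steps bear on this change. Methyl in place of hydrogen gave a 2.9-fold higher number from compound 1 to compound 3 (0.46 log units; beyond the scatter), which is modest. Dimethylamino in place of hydrogen gave an at least 100-fold higher number from compound 1 to compound 2 (2.02 log units; beyond the scatter), which is large and rests on a limit. A modest rise is therefore expected in this assay, with a 2.9-fold higher number from compound 1 to compound 3 (0.46 log units; beyond the scatter) as the closer guide. The expected step is a 2.0-fold higher number from compound 3 to compound 4 (0.30 log units; within the scatter). For compound 4 the estimate is 22000 nM, with an expected range from 7000 nM to 90000 nM.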

Compound 4, half-maximal cytotoxic concentration: 11000 nM
Beside the measured number, compound 4's estimate is 2.0-fold (0.30 log units) above it; measured number inside the range.
By their numbers in this assay, from the lowest: compound 1; then compounds 3 and 4 (each within the scatter of the next). At a limit, above all of these: compound 2.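

In this assay the change from 4-methylphenyl to 4-methoxyphenyl shows no change at the digits printed from compound 3 to compound 4 (within the scatter) and so methoxy and methyl cannot be told apart at this place, while hydrogen does differ from methoxy, with a 2.9-fold higher number from compound 1 to compound 4 (0.46 log units; beyond the scatter) as the same size as the step to methyl. Dimethylamino stands apart from methoxy, with an at least 36-fold lower number from compound 2 to compound 4 (1.56 log units; beyond the scatter) as a large step. That step rests on compound 2, whose value is a limit of the assay and not a number: the limit of > 400000 nM in this assay, at which 1 of the 4 values shown sits.

The compounds shown leave open whether a primary amine or a hydroxyl at this place would stay with methoxy or move toward dimethylamino. They also leave open whether a longer chain, such as ethoxy, would hold the number.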